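The source may report more compounds than this note shows. Statements on the series, on what has been measured and on what is new or still open speak of the compounds shown alone.

In a physicochemical assay for solubility, with a stated time of 18 h, at pH 7.4 (on this read-out higher numbers stand for higher solubility and lower numbers for lower solubility), compound 3 `COc1ccc(Oc2ccc3c(NCCCNCc4cccc(OC)c4O)ccnc3c2)cc1` gives 14500 nM, the second highest of the three numbers in hand. Compound 1 `CC(C)(C)c1ccc(-c2ccc3c(NCCCNCc4ccco4)ccnc3c2)cc1` gives 32000 nM in this assay, a higher number than that of compound 3 and beyond the scatter. Compound 2 `CCC(CC)c1ccc2c(NCCCNCc3ccco3)ccnc2c1` gives 4200 nM in this assay, a lower number than that of compound 3 and also beyond the scatter. Within the data shown here, the only step between measured compounds that differ in one place, a 7.6-fold lower number from compound 1 to compound 2 (0.88 log units; beyond the scatter), concerns a different site of the shared core, and both compound 1 and compound 2 already carry the furan-2-yl group on the chain nitrogen. Compound 4 `COc1ccc(Oc2ccc3c(NCCCNCc4ccco4)ccnc3c2)cc1` is obtained from compound 3 by furan-2-yl in place of 2-hydroxy-3-methoxyphenyl on a saturated chain carbon bound to an amine nitrogen. Among the measured compounds shown here, no measured step covers this change, so no direction is supported by the data; a step within the scatter or a modest one either way remains open. For compound 4 the expected value in this assay is 12000 nM, with a range from 4000 nM to 36000 nM. The step this estimate implies is expected to be a 1.2-fold lower number from compound 3 to compound 4 (0.08 log units; within the scatter).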

Compound 4, solubility: 14500 nM
Estimate against measurement, compound 4: 1.2-fold (0.08 log units) below, and the stated range covers the measured number.
By their numbers in this assay, from the lowest: compound 2; then compounds 3 and 4 (each within the scatter of the next); then compound 1.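

In this assay, among these compounds, the first reading at this position, furan-2-yl in place of 2-hydroxy-3-methoxyphenyl on a saturated chain carbon bound to an amine nitrogen, gives no change at the digits printed from compound 3 to compound 4 (within the scatter) with 4-methoxyphenoxy on the shared core, so the read-out does not separate these two groups here. With furan-2-yl held constant, compound 4 also places 4-methoxyphenoxy on the aromatic carbon among the earlier groups, with a 3.5-fold higher number from compound 2 to compound 4 (0.54 log units; beyond the scatter) against pentan-3-yl and a 2.2-fold lower number from compound 1 to compound 4 (0.34 log units; beyond the scatter) against 4-(tert-butyl)phenyl, so it falls in the middle of the three. No measurement in hand gives a cause for these numbers.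

On these data alone, whether the flat chain step holds with pentan-3-yl or 4-(tert-butyl)phenyl on the aromatic carbon stays open, as 2-hydroxy-3-methoxyphenyl appears only in compound 3. As far as these compounds go, how a carboxylic acid or a morpholine in place of furan-2-yl would read also stays open.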